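This account rests on a few compounds, and the source may have more. Where it says the series, first, only, none or still open, it means among the compounds named here.

The measured compounds are:

compound 1 `O=C(O)C[C@@H]1CCCN1c1ccc(OCc2ccc(Cl)cc2Cl)cc1`, 340 nM in a functional assay on cells for agonist activity at Free fatty acid receptor 1 (Homo sapiens), read by FLIPR and calcium flux, with a stated time of 100 s; a higher number here means that more compound is needed for the effect, a lower number that less compound is needed
compound 2 `Cc1ccccc1Oc1ccc(N2C[C@@H](C(F)(F)F)C[C@H]2CC(=O)O)cc1`, 73 nM
compound 3 `O=C(O)C[C@@H]1CCCN1c1ccc(OCc2ccc(Cl)cc2Cl)cn1`, 220 nM

Among these three, compound 2 has the lowest number in this assay. The nearest to it is compound 3, whose number is higher by a margin that lies beyond the usual scatter, and compound 1 lies further away still, also beyond the scatter. On these numbers compound 2 is therefore the most potent of the three.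

Compound 4 `Cc1ccccc1Oc1ccc(N2CCC[C@H]2CC(=O)O)cc1` keeps the whole of compound 2 except for one change: hydrogen in place of trifluoromethyl on a saturated ring carbon. Among the measured compounds shown here, no two of the measured compounds differ from each other in only this one place, so the data give no measured step of this kind, and the size of the effect has to be estimated rather than read off. The trifluoromethyl group sits on the five-membered ring of compound 2, and its loss is expected to raise the number in this assay by a moderate step, beyond the scatter but not by a large margin, and a result within the scatter cannot be excluded. The expected step from compound 2 to compound 4 is a 2.7-fold higher number from compound 2 to compound 4 (0.44 log units; beyond the scatter). Compound 4 is accordingly expected to give about 200 nM, with a likely range from 70 nM to 600 nM.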

Compound 4, half-maximal effective concentration: 74 nM
The estimate for compound 4 lay 2.7-fold (0.43 log units) above the measured number; low and high end bracket the measured number.
By their numbers in this assay, from the lowest: compounds 2 and 4 (each within the scatter of the next); then compounds 3 and 1 (each within the scatter of the next).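

Taking the trifluoromethyl group off the saturated ring carbon, two ring bonds from the ring nitrogen, gives a 1.0-fold higher number from compound 2 to compound 4 (0.01 log units; within the scatter) in this assay. Among the compounds shown here, this is the first direct reading at this position, as no earlier pair differed only here, and it shows that the trifluoromethyl group, with its 4 heavy atoms, can give way to a single hydrogen without any difference this read-out can separate from the scatter. Nothing among the data shown explains why the two compounds match so closely.

For the compounds shown here, whether other groups on this ring carbon, such as methyl, hydroxyl or a carboxylic acid, would also match compound 4 in this assay remains open, since hydrogen and trifluoromethyl are the only two groups seen here. Also open, as far as these compounds go, is whether trifluoromethyl on the same carbon would leave the number just as unmoved in the core of compound 1, which carries hydrogen there and a different large group on its ring nitrogen side.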